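This account rests on a few compounds, and the source may have more. Where it says the series, first, only, none or still open, it means among the compounds named here.

Measured in an ADME assay for permeability, using PAMPA, with a stated time of 18 h, tested at 25 ug/mL (a higher number here means that the compound crosses the layer faster, a lower number that the compound crosses the layer more slowly), so far:
- Compound 1 `FC(F)(F)c1ccc(CNC2CCN(Cc3ccccc3)C2)cc1` gives 6.3 10^-6 cm/s
- Compound 2 `Fc1ccc(CNC2CCN(Cc3ccccc3)C2)cc1` gives 4.2 10^-6 cm/s

Compound 2 stands level with compound 1 within the scatter. Compound 3 `Fc1ccc(CNC2CCN(Cc3ccccc3)C2)c(F)c1` alters compound 2 in one place (fluoro in place of hydrogen on an aromatic carbon), with fluoro in place of hydrogen on an aromatic carbon. For the measured compounds named here, no measured pair shows this exact change. Going by the values given here, the one measured step that bears on it is a 1.5-fold lower number from compound 1 to compound 2 (0.18 log units; within the scatter), with fluoro in place of trifluoromethyl on an aromatic carbon, so it is only a loose guide. Even that larger exchange of groups stayed small, so no shift beyond the scatter is expected in this assay here, in either direction. The expected size is a 1.2-fold higher number from compound 2 to compound 3 (0.08 log units; within the scatter), which is an estimate and no more. For compound 3 the estimated value is 5 10^-6 cm/s, with an expected range from 2.5 10^-6 cm/s to 10 10^-6 cm/s.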

Compound 3, apparent permeability: 5.8 10^-6 cm/s
Compound 3: the middle estimate sits 1.2-fold (0.06 log units) below what was measured; low and high end bracket the measured number.
By their numbers in this assay, from the lowest: compounds 2, 3 and 1 (each within the scatter of the next).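

In this assay, the step to the difluoro compound gives a 1.4-fold higher number from compound 2 to compound 3 (0.14 log units; within the scatter), so compound 2 and compound 3 stand level within the scatter. The earlier step swapped one group for another, whereas this one puts a single fluorine atom on an aromatic carbon that carried only hydrogen, ortho to a large group and meta to a fluoro group. At this position, then, the fluoro group leaves the number within the scatter of the hydrogen compound, and nothing measured here offers a reason for that.

Still open, going by these compounds, is how this position responds to a group with more atoms, such as methoxy, or to an amine or a carboxylic acid. It is also unclear whether the same fluoro group would behave alike in compound 1, with trifluoromethyl on the ring.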